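Cyclobutyl for tert-butyl on the carbamate oxygen: metabolic stability

The source may hold more compounds than are shown below. What is called first, only, known or untested is meant among the compounds shown, and "the series" means these compounds.

Measured compounds:
compound 1 `CC[C@@H]1C[C@]1(NC(=O)[C@@H]1C[C@@H](Oc2ncc(OC)c3ccc(Cl)cc23)CN1C(=O)[C@@H](NC(=O)OC(C)(C)C)C(C)(C)C)C(=O)NS(=O)(=O)C1CC1`: 0.567 h
compound 2 `COc1cnc(O[C@@H]2C[C@@H](C(=O)N[C@]3(C(=O)NS(=O)(=O)C4CC4)C[C@H]3C(C)C)N(C(=O)[C@@H](NC(=O)OC(C)(C)C)C(C)(C)C)C2)c2cc(Cl)ccc12`: 1.38 h
compound 3 `COc1cnc(O[C@@H]2C[C@@H](C(=O)N[C@]3(C(=O)NS(=O)(=O)C4CC4)C[C@H]3C3CC3)N(C(=O)[C@@H](NC(=O)OC(C)(C)C)C(C)(C)C)C2)c2cc(Cl)ccc12`: 1.38 h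

In an ADME assay on liver (Homo sapiens) for metabolic stability, using microsomes (a lower number here means that the compound disappears faster, a higher number that the compound lasts longer), compound 3 stands level with compound 2, and the two together give the highest of the three numbers; compound 1 sits furthest away, with a 2.4-fold higher number from compound 1 to compound 3 (0.39 log units; beyond the scatter). Compound 4 `COc1cnc(O[C@@H]2C[C@@H](C(=O)N[C@]3(C(=O)NS(=O)(=O)C4CC4)C[C@H]3C3CC3)N(C(=O)[C@@H](NC(=O)OC3CCC3)C(C)(C)C)C2)c2cc(Cl)ccc12` differs from compound 3 by cyclobutyl in place of tert-butyl on an oxygen next to a carbonyl group. The measured steps, a 2.4-fold higher number from compound 1 to compound 2 (0.39 log units; beyond the scatter) and no change at the digits printed from compound 2 to compound 3 (within the scatter) among them, all concern a saturated ring carbon, not the oxygen next to a carbonyl group, so none of them bears on this change. With nothing to guide direction, compound 4 is expected to stay close to compound 3, with a 1.2-fold lower number from compound 3 to compound 4 (0.06 log units; within the scatter) not beyond the scatter. Compound 4 is therefore estimated at 1.2 h, in a range from 0.5 h to 2.8 h.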

Compound 4, half-life: 0.967 h
The estimate for compound 4 lay 1.2-fold (0.09 log units) above the measured number; low and high end bracket the measured number.
By their numbers in this assay, from the lowest: compounds 1, 4, 2 and 3 (each within the scatter of the next, the first and the last beyond it).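

In this assay, the first change shown on an oxygen next to a carbonyl group, cyclobutyl in place of tert-butyl, gives a 1.4-fold lower number from compound 3 to compound 4 (0.15 log units; within the scatter). Among these compounds, this position therefore accepts a four-membered ring of carbon in place of the open tert-butyl group without a step beyond the scatter, which the earlier steps, all on a saturated ring carbon, could not show. Nothing measured here accounts for this result.

From the compounds shown here alone, whether the same oxygen accepts methyl, oxetanyl or a longer chain remains open. So does whether cyclobutyl there reads the same alongside the isopropyl of compound 2 or the ethyl of compound 1.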